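Triazole-bearing chromone series: cytotoxicity working notes

The source may report more compounds than this note shows. Statements on the series, on what has been measured and on what is new or still open speak of the compounds shown alone.

Measured compounds:
compound 1 `COc1cc(OC)c2c(=O)cc(-c3ccc(OCc4cn(-c5ccc(F)cc5F)nn4)c(OCc4cn(-c5ccc(F)cc5F)nn4)c3)oc2c1`: > 100 ug/mL
compound 2 `COc1cc(OC)c2c(=O)cc(-c3ccc(OCc4cn(-c5ccccc5Cl)nn4)c(OCc4cn(-c5ccccc5Cl)nn4)c3)oc2c1`: > 100 ug/mL
compound 3 `COc1cc(OC)c2c(=O)cc(-c3ccc(OCc4cn(-c5ccc(Cl)cc5)nn4)c(OC)c3)oc2c1`: > 100 ug/mL

In an ADME assay on Huh-7 cells (Homo sapiens) for cytotoxicity, read by MTT assay, with a stated time of 72 h (on this read-out higher numbers stand for lower toxicity in this test and lower numbers for higher toxicity in this test), compound 1 gives > 100 ug/mL, which is a limit of the test and not a number. Compound 2 gives > 100 ug/mL, again a limit. Compound 3 gives > 100 ug/mL, likewise a limit. Within the data shown here, compound 3 therefore stands where every value so far stands, at the limit of > 100 ug/mL in this assay, at which 3 of the 3 values shown sit; nothing in these three values separates compound 3 from compound 1 or compound 2, and no pair of measured compounds differs in a single place, so no measured step is available.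

Compound 4 `COc1cc(OC)c2c(=O)cc(-c3ccc(OCc4cn(-c5ccc(F)c(Cl)c5)nn4)c(OC)c3)oc2c1` is not yet measured. It differs from compound 3 by 3-chloro-4-fluorophenyl in place of 4-chlorophenyl on an aromatic nitrogen. With all three measured compounds sitting at the same limit, the step expected in this assay from compound 3 to compound 4, a step that the limit leaves unreadable from compound 3 to compound 4, is none beyond the scatter, and the most likely outcome is that compound 4 also reports only a limit. Compound 4 is therefore estimated at 150 ug/mL, with a range from 60 ug/mL to 400 ug/mL.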

Compound 4, half-maximal cytotoxic concentration: > 100 ug/mL
Compound 4: only a limit was reported; the forecaster's own chance of this, stated with the estimate: 80%; the middle value does not contradict the limit.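

In this assay compound 4 gives > 100 ug/mL, which is a limit and not a number. No step from compound 3 to compound 4 can be read, because both report only a limit: the limit of > 100 ug/mL in this assay, at which 4 of the 4 values shown sit.

The compounds shown leave open what numerical cytotoxic concentration any of them has, and whether 3-chloro-4-fluorophenyl in place of 4-chlorophenyl changes it.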